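Swapping Methoxy for Fluoro and Cytotoxicity in Liver Cells

This account rests on a few compounds, and the source may have more. Where it says the series, first, only, none or still open, it means among the compounds named here.

Compound 1 `COc1ccc(-c2ccc3c(NCCCNCc4cccc(OC)c4O)ccnc3c2)cc1` and compound 2 `COc1cccc(CNCCCNc2ccnc3cc(-c4ccc(F)cc4)ccc23)c1O` share one core and differ in a single spot: fluoro in place of methoxy on an aromatic carbon. In an ADME assay on HepG2 cells (Homo sapiens) for cytotoxicity, read by luminescence, CellTiter-Glo and ATP content, with a stated time of 72 h (a higher number here means that more compound is needed for the effect, a lower number that less compound is needed), compound 1 gives 1600 nM, while compound 2 gives 6840 nM, so this change brought a 4.3-fold higher number from compound 1 to compound 2 (0.63 log units; beyond the scatter). Compound 3 `COc1ccc(Oc2ccc3c(NCCCNCc4cc(F)ccc4OC)ccnc3c2)cc1` carries a different core; how the two cores differ is not broken down here. In this assay compound 3 gives 7000 nM. Compound 4 `COc1ccc(F)cc1CNCCCNc1ccnc2cc(Oc3ccc(F)cc3)ccc12` is not yet measured and differs from compound 3 by fluoro in place of methoxy on an aromatic carbon, the same change made on the same kind of place. Because compound 3 already gives 7000 nM and the earlier step was a 4.3-fold higher number from compound 1 to compound 2 (0.63 log units; beyond the scatter), the expected step is a 2.6-fold higher number from compound 3 to compound 4 (0.41 log units; beyond the scatter). The earlier step rests on one pair alone, so a somewhat smaller shift is expected. Compound 4 is estimated at 18000 nM, plausibly between 7000 nM and 45000 nM.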

Compound 4, half-maximal effective concentration: 6600 nM
The estimate for compound 4 lay 2.7-fold (0.44 log units) above the measured number; the measured number lies below the stated range.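

In this assay fluoro in place of methoxy on the core of compound 3 gives a 1.1-fold lower number from compound 3 to compound 4 (0.03 log units; within the scatter) and so no shift beyond the scatter. The same change therefore does not act alike on the two cores: the same change on two cores in this assay, a 4.3-fold higher number (0.63 log units; beyond the scatter) from compound 1 to compound 2 and a 1.1-fold lower number (0.03 log units; within the scatter) from compound 3 to compound 4, 4.5-fold (0.66 log units) apart, beyond the scatter of two such steps

The step measured on one core cannot be carried over to the other as a fixed shift in this series. Among the compounds shown here, with only two pairs, this does not show which part of the cores sets the gap, or how the change would behave on any further core.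

From the compounds shown here alone, whether an amine or a chloro group at this place would follow either step remains open. So does the outcome on both cores with a longer chain joining the two amine nitrogens.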